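Sulfonyl in place of acyl on the ring nitrogen

The compounds below may be only part of what the source reports. "The series", "measured", "known", "first", "only" and "open" are said of these compounds alone.

Measured so far:
- compound 1 `CC(=O)N1N=C(c2ccc(N3CCN(C)CC3)cc2)CC1c1ccc(N(C)C)cc1`: -1%
- compound 2 `CN1CCN(c2ccc(C3=NN(C(=O)c4ccc(F)cc4)C(c4ccc(N(C)C)cc4)C3)cc2)CC1`: 3.5%

Both measured compounds were tested in a functional assay on MDA-MB-231 cells (Homo sapiens) for inhibition, read by sulforhodamine B assay, tested at 10 uM; a lower number here means less inhibition, a higher number more inhibition at the concentration tested (going by the name of the read-out). Compound 1 gives -1%. Within the data shown here, compound 2 gives 3.5%, the higher of the two numbers, but the only step so far, a number 4.5 percentage points higher from compound 1 to compound 2 (within the scatter), is within the scatter, so the two values cannot be told apart.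

Compound 3 `CN1CCN(c2ccc(C3=NN(S(=O)(=O)c4ccc(Br)cc4)C(c4ccc(N(C)C)cc4)C3)cc2)CC1` has not been measured. It differs from compound 2 as follows: (4-bromophenyl)sulfonyl in place of (4-fluorophenyl)carbonyl on an amine nitrogen in a ring. Among the measured compounds shown here, no measured step exchanges a carbonyl for a sulfonyl or a fluorine for a bromine on this aromatic ring, so the only guidance is that the one measured step on the same nitrogen stayed within the scatter.

Compound 3 is therefore expected to show no step beyond the scatter, a number 1.5 percentage points higher from compound 2 to compound 3 (within the scatter). The estimate for compound 3 is 5%, with a range from -10% to 22%.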

Compound 3, a percentage reported as inhibition, at one concentration (the size of the read-out at that concentration, not a potency): 23.7%
Beside the measured number, compound 3's estimate is 18.7 percentage points below it; the whole stated range lies below it.
By their numbers in this assay, from the lowest: compounds 1 and 2 (each within the scatter of the next); then compound 3.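

In this assay the amine nitrogen in the ring now shows that its substituent can move the read-out: the step of a number 20.2 percentage points higher from compound 2 to compound 3 (beyond the scatter) comes with (4-bromophenyl)sulfonyl in place of (4-fluorophenyl)carbonyl, and the step of a number 24.7 percentage points higher from compound 1 to compound 3 (beyond the scatter) comes with (4-bromophenyl)sulfonyl in place of acetyl. Among these compounds, the two carbonyl-linked groups could not be told apart, so this is the first step at this position beyond the scatter. The sulfonyl and the bromine enter together, so neither can be credited with the step alone, and nothing available explains the step.

The compounds shown leave open whether the sulfonyl or the bromine accounts for the step, which a (4-fluorophenyl)sulfonyl or a (4-bromophenyl)carbonyl group would separate. Also open, as far as these compounds go, is how a methylsulfonyl group would compare on the same nitrogen.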